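Aryl group changes on the shared core: working notes

A few compounds are considered here, and "the series" means these few. Any claim that something is new, unique, unknown or untested is made for them only; others in the source may bear on it.

Values in an ADME assay (liver) for metabolic stability, with Liver microsome (Rattus norvegicus) as the target, read by LC-MS, using microsomes, with a stated time of 30 min, tested at 4 uM; on this read-out lower numbers stand for a less stable compound and higher numbers for a more stable compound:
- compound 1 `Cc1nc(N2CCN(C)CC2)c2nc(-c3cccc(C(F)(F)F)c3)n(C3CCOCC3)c2n1`: 28%
- compound 2 `COc1ccccc1-c1nc2c(N3CCN(C)CC3)nc(C)nc2n1C1CCOCC1`: 35%

Compound 2 stands within the scatter of compound 1, so the two cannot be ranked in this assay. Compound 3 `Cc1nc(N2CCN(C)CC2)c2nc(-c3ccccc3F)n(C3CCOCC3)c2n1` has not yet been measured. It carries fluoro in place of methoxy on an aromatic carbon, ortho to a large group, which turns 2-methoxyphenyl into 2-fluorophenyl: fluoro in place of methoxy on an aromatic carbon.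

For the measured compounds named here, only one measured step bears on this change. It also alters the aryl group, exchanging 3-(trifluoromethyl)phenyl for 2-methoxyphenyl, and it reads a number 7 percentage points higher from compound 1 to compound 2 (within the scatter). Going by the values given here, no measured compound carries fluoro as such, and a single step gives only weak guidance, so the range has to stay wide. No change beyond the scatter is therefore expected, and the expected step is a number 3 percentage points higher from compound 2 to compound 3 (within the scatter). The estimated value for compound 3 is 38%, with an expected range from 22% to 55%.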

Compound 3, percent of the compound remaining: 30%
The estimate for compound 3 lay 8 percentage points above the measured number; the measured number falls inside the stated range.
By their numbers in this assay, from the lowest: compounds 1, 3 and 2 (each within the scatter of the next).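

In this assay, fluoro in place of methoxy on an aromatic carbon, ortho to a large group, gives a number 5 percentage points lower from compound 2 to compound 3 (within the scatter) and so separates neither compound from the other; at this place, the read-out does not distinguish the larger methoxy, with its hydrogen-bond acceptor, from the single fluorine atom. The comparison of 2-fluorophenyl with 3-(trifluoromethyl)phenyl gives a number 2 percentage points higher from compound 1 to compound 3 (within the scatter), which means that all three aryl groups shown now lie within the scatter of one another and none of them can be ranked for stability in these microsomes. No measured property bears on this result, so the data offer no account of it.

From the compounds shown here alone, all three aryl groups are phenyl rings carrying one neutral substituent, so it remains open whether an amine or a carboxylic acid on the same aromatic carbon would move the percent remaining beyond the scatter. The other groups on the shared core are identical in compounds 1, 2 and 3, which leaves open how changes at those places would read in this assay.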